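Chlorine position on the benzylamine side chain of compound 1

The compounds below may be only part of what the source reports. "The series", "measured", "known", "first", "only" and "open" are said of these compounds alone.

Working notes on the series. Compound 1 is `O=S(=O)(NCCCNCc1ccccc1Cl)c1cc(C(F)(F)F)cc(C(F)(F)F)c1`. In a functional assay on PANC-1 cells (Homo sapiens) for inhibition, read by MTT assay, with a stated time of 72 h (on this read-out lower numbers stand for stronger inhibition of growth and higher numbers for weaker inhibition of growth), compound 1 gives 15000 nM, the highest of the two numbers recorded here. Compound 3 is `O=S(=O)(NCCCNCc1cccc(Cl)c1)c1cc(C(F)(F)F)cc(C(F)(F)F)c1`; in this assay compound 3 gives 12000 nM, and the pair shows a 1.3-fold lower number from compound 1 to compound 3 (0.10 log units; within the scatter). Compound 2 is `CN(CCCNS(=O)(=O)c1cc(C(F)(F)F)cc(C(F)(F)F)c1)Cc1ccccc1`. In this assay compound 2 is reported only as a limit, > 50000 nM, not as a number (the limit of > 50000 nM in this assay, at which 1 of the 3 values shown sits). The steps of an at least 3.3-fold higher number from compound 1 to compound 2 (0.52 log units; beyond the scatter) and an at least 4.1-fold lower number from compound 2 to compound 3 (0.61 log units; beyond the scatter) concern a different change at the amine and do not move the chlorine on its own.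

Compound 4 is `O=S(=O)(NCCCNCc1ccc(Cl)cc1)c1cc(C(F)(F)F)cc(C(F)(F)F)c1`. Against compound 1 the difference is 4-chlorophenyl in place of 2-chlorophenyl on a saturated chain carbon bound to an amine nitrogen. Going by the values given here, the only measured step that bears on it, a 1.3-fold lower number from compound 1 to compound 3 (0.10 log units; within the scatter), stayed within the scatter, so no step beyond the scatter is expected in this assay from compound 1 to compound 4. Compound 4 is therefore estimated at 12000 nM, with a range of 5000 nM to 30000 nM. The expected step is a 1.3-fold lower number from compound 1 to compound 4 (0.10 log units; within the scatter).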

Compound 4, concentration for 50% growth inhibition: 4900 nM
For compound 4 the middle estimate is 2.4-fold (0.39 log units) above the measured one, and the stated range ends above it.
By their numbers in this assay, from the lowest: compound 4; then compounds 3 and 1 (each within the scatter of the next). At a limit, above all of these: compound 2.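

In this assay, the chlorine position now gives a change beyond the scatter, which the step between 2-chlorophenyl and 3-chlorophenyl did not: 4-chlorophenyl gives both (a 3.1-fold lower number from compound 1 to compound 4 (0.49 log units; beyond the scatter)) and (a 2.4-fold lower number from compound 3 to compound 4 (0.39 log units; beyond the scatter)), leaving compound 4 the most active of the compounds shown. Set against the benzyl(methyl)amino side chain, the (4-chlorobenzyl)amino side chain gives the largest step recorded so far in this series (an at least 10-fold lower number from compound 2 to compound 4 (1.00 log units; beyond the scatter)). Compound 2 is reported only as a limit, not as a number: the limit of > 50000 nM in this assay, at which 1 of the 4 values shown sits.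

From the compounds shown here alone, it remains open whether the step belongs to chlorine itself or would also appear with 4-fluorophenyl, 4-bromophenyl or 4-methoxyphenyl. Going by these compounds, it is also open how compound 4 would respond to a methyl group on its amine nitrogen or to a longer chain between the two nitrogens.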